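Heptyl in place of phenyl on an aminoquinone core

The compounds below may be only part of what the source reports. "The series", "measured", "known", "first", "only" and "open" are said of these compounds alone.

For the measured compounds named here, compound 1 `CC(C)(C)C1=CC(=O)C(NCc2ccccc2)=CC1=O` is the only compound here with a measured number: in a functional assay on NCI-H460 cells (Homo sapiens) for cytotoxicity, read by MTT assay, with a stated time of 72 h (on this read-out higher numbers stand for weaker inhibition and lower numbers for stronger inhibition), compound 1 gives 15000 nM. Compound 2 `CCCCCCCCNC1=CC(=O)C(C[C@]2(C)[C@@H](C)CC[C@]3(C)C(C)=CCC[C@@H]23)=CC1=O` returns only a limit in this assay, namely > 100000 nM, which is where the limit of > 100000 nM in this assay, at which 1 of the 2 values shown sits, places it. Compound 3 `CCCCCCCCNC1=CC(=O)C(C(C)(C)C)=CC1=O` has not yet been measured. It differs from compound 1 in one place (heptyl in place of phenyl on a saturated chain carbon bound to an amine nitrogen). Going by the values given here, no two measured compounds here differ in a single place, so the size of such a step cannot be read from the data; compound 2 also carries a chain on the nitrogen, but it bears a different group on the shared core, so its limit alone is not a guide. A modest weakening is expected, a 1.7-fold higher number from compound 1 to compound 3 (0.22 log units; within the scatter), and it may well stay within the usual scatter. For compound 3 in this assay the estimate is 25000 nM, with a range from 8000 nM to 90000 nM.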

Compound 3, half-maximal inhibitory concentration: 65000 nM
Compound 3: middle estimate off by 2.6-fold (0.41 log units), on the low side; the measured number falls inside the stated range.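

In this assay, the change at this place can now be read: heptyl in place of phenyl on a saturated chain carbon bound to an amine nitrogen gives a 4.3-fold higher number from compound 1 to compound 3 (0.64 log units; beyond the scatter) on the shared core. This open chain without a ring therefore costs inhibition beyond the usual scatter, though compound 3 still returns a measured number and not a limit. Compound 2, which carries the same chain on the nitrogen and a different group on the core, stays at a limit of the assay: the limit of > 100000 nM in this assay, at which 1 of the 3 values shown sits.

The compounds shown leave open whether the loss follows from removing the aromatic ring or from the chain itself, which a cyclohexyl group or a shorter propyl chain could separate. They also do not show how a methoxy-substituted phenyl or an amine on the heptyl chain would behave.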